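This account rests on a few compounds, and the source may have more. Where it says the series, first, only, none or still open, it means among the compounds named here.

Measured so far in a functional assay on the whole organism (strain Kunming) for inhibition, with Mus musculus as the target, with a stated time of 1 h, at a dose of 40 mg/kg by the oral route; a lower number here means less inhibition, a higher number more inhibition at the dose given (going by the name of the read-out):
compound 1 `O=C(/C=C/c1ccccc1)c1ccc(N2CCN(c3ccc([N+](=O)[O-])cc3)CC2)cc1` gives 55.4%;
compound 2 `O=C(/C=C/c1ccccc1)c1ccc(N2CCN(c3cccc(C(F)(F)F)c3)CC2)cc1` gives 25%;
compound 3 `O=C(/C=C/c1ccccc1)c1ccc(N2CCN(S(=O)(=O)c3ccc(Br)cc3)CC2)cc1` gives 47.4%.

Compound 3 stands second highest of the three numbers: the step of a number 8 percentage points lower from compound 1 to compound 3 (within the scatter) lies within the scatter, while a number 22.4 percentage points higher from compound 2 to compound 3 (beyond the scatter) lies beyond it. Compound 4 `CCCCc1ccc(S(=O)(=O)N2CCN(c3ccc(C(=O)/C=C/c4ccccc4)cc3)CC2)cc1` differs from compound 3 in one place only: butyl in place of bromo on an aromatic carbon, on an aromatic carbon of a six-membered aromatic ring of carbon only. Within the data shown here, the two measured steps into compound 3 each exchange the whole group on the amine nitrogen in the ring; neither alters a substituent on the ring that stays in place, so no measured step bears directly on this change. With nothing pointing either way, the step of a number 2.4 percentage points lower from compound 3 to compound 4 (within the scatter) is expected to stay within the scatter in this assay. Compound 4 is estimated at 45%, between 25% and 65%.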

Compound 4, a percentage reported as inhibition, in the whole organism at one dose (the size of the read-out at that dose, not a potency): 24%
Beside the measured number, compound 4's estimate is 21 percentage points above it; the measured number lies below the stated range.
By their numbers in this assay, from the lowest: compounds 4 and 2 (each within the scatter of the next); then compounds 3 and 1 (each within the scatter of the next).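

Changing only the small substituent, para to a large group, matters here: in this assay, butyl in place of bromo gives a number 23.4 percentage points lower from compound 3 to compound 4 (beyond the scatter). The earlier steps shown here exchanged the whole group on the amine nitrogen, whereas this one shows that an outer substituent on the aromatic ring can also move the number beyond the scatter. No measurement here offers an explanation for this step.

The compounds shown leave open whether any replacement of bromo has this effect or whether it depends on the chain. Methyl, chloro or methoxy at the same place would help to separate these possibilities.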